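Turning one ring carbon: the mirror form of compound 1

The source may hold more compounds than are shown below. What is called first, only, known or untested is meant among the compounds shown, and "the series" means these compounds.

Measured compounds:
compound 1, `COc1cc2nc(N3CCC[C@@H](NC(=O)c4ccco4)C3)nc(N)c2cc1OC`: 42.7 nM
compound 2, `COc1cc2nc(N3CCC[C@@H](N)C3)nc(N)c2cc1OC`: 178 nM
compound 3, `COc1cc2nc(N3CCC[C@H](NC4=CC(=O)c5ccccc5C4=O)C3)nc(N)c2cc1OC`: 0.525 nM

All three compounds share a core and were tested in an assay on CHO cells for displacement of a labelled ligand from Alpha-1B adrenergic receptor (Homo sapiens), with a stated time of 30 min; on this read-out lower numbers stand for stronger inhibition and higher numbers for weaker inhibition. Compound 1 gives 42.7 nM, the second highest of the three numbers; its nearest neighbour is compound 2, the compound with the higher number, and the furthest is compound 3, with a far lower number. Within the data shown here, the only single-change step measured is a 4.2-fold higher number from compound 1 to compound 2 (0.62 log units; beyond the scatter), which shows that the (furan-2-yl)carbonyl group matters for binding.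

Compound 4, `COc1cc2nc(N3CCC[C@H](NC(=O)c4ccco4)C3)nc(N)c2cc1OC`, has not been measured. It differs from compound 1 in this way: the two compounds have the same atoms and bonds and differ only in configuration as drawn: 1 of 1 stereo elements differ; a stereocentre at a saturated ring carbon is drawn R in compound 1 and S in compound 4. Among the measured compounds shown here, no measured step bears on this change: compound 2 keeps the configuration of compound 1, and compound 3 carries a different substituent, so its low number cannot be read as a pure effect of configuration. With no evidence either way, no step beyond the scatter is expected, but the uncertainty is wide: the expected step is a 1.1-fold lower number from compound 1 to compound 4 (0.03 log units; within the scatter). Compound 4 is therefore estimated at 40 nM, within a range from 8 nM to 200 nM.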

Compound 4, inhibition constant: 0.282 nM
The estimate for compound 4 lay 140-fold (2.15 log units) above the measured number, and the stated range ends above it.
By their numbers in this assay, from the lowest: compounds 4 and 3 (each within the scatter of the next); then compound 1; then compound 2.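

In this assay, among these compounds, the step to the mirror form, a 150-fold lower number from compound 1 to compound 4 (2.18 log units; beyond the scatter), shows that the configuration at this one saturated ring carbon has a large effect on the number, which no earlier pair could show. This step is much larger than a 4.2-fold higher number from compound 1 to compound 2 (0.62 log units; beyond the scatter), so in this small set, turning the ring carbon moves the number far more than removing the (furan-2-yl)carbonyl group from the amine nitrogen does. The gap can be put down to configuration alone, because nothing else separates the two structures: the fact that compounds 1 and 4 differ only in the configuration as drawn

As far as these compounds go, it remains open whether the mirror forms of compound 2 and compound 3 would show a gap of similar size, so the effect of turning this carbon is known only for the compounds carrying the (furan-2-yl)carbonyl group. Also open, from the compounds shown here alone, is how other groups on that nitrogen, such as a simple acetyl group or a longer chain ending in a carboxylic acid, would behave in the configuration drawn in compound 4.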